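The compounds below may be only part of what the source reports. "The series", "measured", "known", "first", "only" and "open" are said of these compounds alone.

Measured compounds:
compound 1, `COC(=O)[C@H]1C(/C=C/C(=O)c2ccc([N+](=O)[O-])cc2)=Cc2cc(OC)c(OC)cc2[C@H]1c1cc(OC)c(OC)c(OC)c1`, 16.8 ug/mL in a functional assay on A549 cells (Homo sapiens) for cytotoxicity, read by sulforhodamine B assay; a lower number here means a stronger inhibitor, a higher number a weaker inhibitor
compound 2, `COC(=O)[C@H]1C(/C=C/C(=O)c2ccc(O)cc2)=Cc2cc(OC)c(OC)cc2[C@H]1c1cc(OC)c(OC)c(OC)c1`, 6.79 ug/mL
compound 3, `COc1cc2c(cc1OC)[C@@H](c1cc(OC)c(OC)c(OC)c1)[C@H](C(=O)N1CCCC1)C(/C=C/C(=O)c1ccc(C3CCCCC3)cc1)=C2`, 12 ug/mL

Compound 3 carries a pyrrolidine amide and a cyclohexyl substituent on the aryl ketone, and its value in this assay lies within the usual scatter of those of both compound 1 and compound 2, so no order among these three can be claimed from it. Among the measured compounds shown here, the one step that is resolved, a 2.5-fold lower number from compound 1 to compound 2 (0.39 log units; beyond the scatter), concerns a change on the aryl ketone that is unrelated to the change now considered.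

Compound 4, `COc1cc2c(cc1OC)[C@@H](c1cc(OC)c(OC)c(OC)c1)[C@H](C(=O)N1CCCC1)C(/C=C/C(=O)c1ccc(-c3ccccc3)cc1)=C2`, differs from compound 3 by phenyl in place of cyclohexyl on an aromatic carbon. For the measured compounds named here, no measured pair in this set exchanges a saturated for an aromatic ring at this place, so there is no step that bears on the change directly; the only resolved step, from compound 1 to compound 2, involves a different pair of groups. The expectation is therefore a step of no change at the digits printed from compound 3 to compound 4 (within the scatter), that is, none beyond the scatter. Compound 4 is estimated at 12 ug/mL in this assay, with a range from 6 ug/mL to 24 ug/mL.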

Compound 4, half-maximal inhibitory concentration: 24.6 ug/mL
Compound 4: the middle estimate sits 2.1-fold (0.31 log units) below what was measured; the measured number lies above the stated range.
By their numbers in this assay, from the lowest: compounds 2, 3, 1 and 4 (each within the scatter of the next, the first and the last beyond it).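

With the pyrrolidine amide held fixed, the exchange of 4-cyclohexylphenyl for 4-phenylphenyl gives a 2.1-fold higher number from compound 3 to compound 4 (0.31 log units; beyond the scatter) in this assay, so two groups with the same heavy-atom count and no hydrogen-bond donors or acceptors are told apart at this place. Among the compounds shown here, until now the only resolved step on this aryl ketone was a 2.5-fold lower number from compound 1 to compound 2 (0.39 log units; beyond the scatter), an exchange of nitro for hydroxy; the new step shows that a change of ring type alone, from non-aromatic to aromatic, also moves the number beyond the scatter. Nothing given here accounts for the size or direction of this step.

For the compounds shown here, compound 3 and compound 4 are the only pair with this change, so whether it holds with the methyl ester in place of the pyrrolidine amide stays open. On these data alone, how a smaller group such as methyl, or an amine or a carboxylic acid on the same aromatic carbon, would stand also remains unknown.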